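A few compounds are considered here, and "the series" means these few. Any claim that something is new, unique, unknown or untested is made for them only; others in the source may bear on it.

Measured compounds:
Compound 1, `O=C1CCC(=O)N1Cc1cc2nccc(-c3cc(Cl)cc4c3O[C@@H](c3ocnc3CN3CCC3)C4)c2s1`: 13 nM
Compound 2, `O=C([C@H]1Cc2cc(Cl)cc(-c3ccnc4cc(Cn5cnccc5=O)sc34)c2O1)N1CCNCC1`: 27 nM

Both compounds were tested in an assay on isolated protein for inhibition of ubiquitin carboxyl-terminal hydrolase 7 (Homo sapiens), read by fluorescence, with stated times of 30 min and 1 h; a higher number here means a weaker inhibitor, a lower number a stronger inhibitor. Of the two numbers, compound 1 has the lower one, so it is the stronger inhibitor here; compound 2 gives the higher number, and the gap between them lies beyond the usual scatter of repeated measurements. Since the two compounds differ in more than one place, nothing about any single change can be drawn from this pair; only the two values themselves can be compared.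

The next compound, compound 3, `Cn1nc2c(c1[C@H]1Cc3cc(Cl)cc(-c4ccnc5cc(CN6C(=O)CCC6=O)sc45)c3O1)CNCC2`, has not yet been measured in this assay. It is derived from compound 1 by one change on a saturated ring carbon of the shared core: a group of 10 heavy atoms (7 carbon, 3 nitrogen; one five-membered aromatic ring with 2 hetero atoms, one six-membered non-aromatic ring with 1 hetero atom) in place of a group of 10 heavy atoms (7 carbon, 2 nitrogen, 1 oxygen; one four-membered non-aromatic ring with 1 hetero atom, one five-membered aromatic ring with 2 hetero atoms), on a saturated ring carbon

Going by the values given here, no step between measured compounds is available to guide this change, so the expectation rests on the size of groups exchanged being equal and on compound 1 giving 13 nM. The step from compound 1 to compound 3 is expected to be small, a 1.9-fold higher number from compound 1 to compound 3 (0.28 log units; within the scatter), in the direction of a slightly weaker inhibitor but not clearly beyond the scatter. Compound 3 is therefore estimated at 25 nM, with a range from 8 nM to 80 nM.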

Compound 3, half-maximal inhibitory concentration: 1.1 nM
Estimate against measurement, compound 3: 23-fold (1.36 log units) above, outside the stated range (below it).
By their numbers in this assay, from the lowest: compound 3; then compound 1; then compound 2.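

On the saturated ring carbon next to the ring oxygen, replacing the 4-((azetidin-1-yl)methyl)-1,3-oxazol-5-yl group with a fused group of the same heavy-atom count gives a 12-fold lower number from compound 1 to compound 3 (1.07 log units; beyond the scatter) in this assay. This shows that the number at this position depends strongly on which group is present, not only on its size, since both groups have the same heavy-atom count and each contains a five-membered aromatic ring. The entering group also has one hydrogen-bond donor where the leaving group has none, but no measurement shown explains the large step.

The exchange alters the whole group at once, so the compounds shown do not separate the contribution of the six-membered non-aromatic ring from that of the five-membered aromatic ring, nor show whether the hydrogen-bond donor matters. An acetyl group on the nitrogen of the six-membered ring, or an open-chain amine in place of that ring, would help to separate these contributions.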